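Swapping the outer phenyl for a dichloropyridyl ring

A few compounds are considered here, and "the series" means these few. Any claim that something is new, unique, unknown or untested is made for them only; others in the source may bear on it.

Measured so far:
compound 1 `O=C(O)c1ccc2noc(-c3ccc(-c4ccncc4)cc3)c2c1`, 150 nM
compound 2 `O=C(O)c1ccc2noc(-c3ccc(Cc4ccccc4)cc3)c2c1`, 65 nM
compound 3 `O=C(O)c1ccc2noc(-c3ccc(Oc4ccccc4)cc3)c2c1`, 280 nM

All three compounds share one core and differ only in the group attached to its outer aromatic ring. In an assay for inhibition of inositol hexakisphosphate kinase 2 (Homo sapiens), read by colorimetric assay, coupled enzyme assay and malachite green, with a stated time of 120 min, in the presence of a further agent that is not named here (on this read-out higher numbers stand for weaker inhibition and lower numbers for stronger inhibition), compound 3 gives the highest number of the three; the step of a 1.9-fold higher number from compound 1 to compound 3 (0.27 log units; within the scatter) lies within the scatter, while the step of a 4.3-fold higher number from compound 2 to compound 3 (0.63 log units; beyond the scatter) stands beyond it. The step of a 2.3-fold lower number from compound 1 to compound 2 (0.36 log units; beyond the scatter) is the other comparison available.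

Compound 4 `O=C(O)c1ccc2noc(-c3ccc(Oc4ncc(Cl)cc4Cl)cc3)c2c1` keeps the oxygen-linked arrangement of compound 3 and alters the ring beyond the oxygen: 3,5-dichloropyridin-2-yl in place of phenyl on an oxygen on an aromatic ring.

Among the compounds with values here, none of the measured steps touches this position. The steps from compound 1 to compound 2, from compound 1 to compound 3 and from compound 2 to compound 3 all concern what sits directly on the outer ring of the core, not the distant ring itself, so they give no direct guide to the change in compound 4. With nothing to lean on, the expectation for compound 4 in this assay is a number close to that of compound 3, a step of a 1.1-fold lower number from compound 3 to compound 4 (0.05 log units; within the scatter), with a wide range either way. The estimate for compound 4 is 250 nM, between 70 nM and 900 nM.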

Compound 4, half-maximal inhibitory concentration: 650 nM
Beside the measured number, compound 4's estimate is 2.6-fold (0.41 log units) below it, and the stated range covers the measured number.
By their numbers in this assay, from the lowest: compound 2; then compounds 1 and 3 (each within the scatter of the next); then compound 4.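

In this assay, the ring beyond the oxygen proves to be a position that counts: 3,5-dichloropyridin-2-yl in place of phenyl gives a 2.3-fold higher number from compound 3 to compound 4 (0.37 log units; beyond the scatter), so this change at the far end of the molecule costs inhibition rather than leaving it unchanged. Compound 4 is also the weakest inhibitor of the four, as shown by a 4.3-fold higher number from compound 1 to compound 4 (0.64 log units; beyond the scatter) and a 10-fold higher number from compound 2 to compound 4 (1.00 log units; beyond the scatter), although these two steps replace the whole group on the outer ring and so do not isolate the effect of the far ring. No measurement at hand bears on why the number rises.

This swap brings in the ring nitrogen and the chlorine atoms together, so the compounds shown cannot say which of them accounts for the step; a plain pyridin-2-yl ring and a 3,5-dichlorophenyl ring on the same oxygen would pull the two apart. Also open, going by these compounds, is whether 3,5-dichloropyridin-2-yl would give a similar step on the carbon link of compound 2, the compound with the lowest number here.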